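Configuration change from compound 2 to compound 3

The source may report more compounds than this note shows. Statements on the series, on what has been measured and on what is new or still open speak of the compounds shown alone.

In an ADME assay on microsomes from liver (Mus musculus) for metabolic stability, read by LC-MS, with a stated time of 10 min (on this read-out lower numbers stand for a less stable compound and higher numbers for a more stable compound), compound 2 `CN(C[C@H]1Cc2c(cccc2N2C[C@@H]3C[C@H]2CN3)CN1)[C@H]1CCCc2cccnc21` gives 36.3%, and compound 1 `CN(C[C@H]1Cc2c(cccc2N2CCN3CCC[C@H]3C2)CN1)[C@H]1CCCc2cccnc21` gives 40.1%. For the measured compounds named here, these are the only two measured values, and the single measured step is a number 3.8 percentage points lower from compound 1 to compound 2 (within the scatter). Going by the values given here, compound 2 therefore stands level with its one neighbour on this read-out.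

Compound 3 `CN(C[C@H]1Cc2c(cccc2N2C[C@H]3C[C@@H]2CN3)CN1)[C@H]1CCCc2cccnc21` has not yet been measured. Its difference from compound 2 is the two compounds have the same atoms and bonds and differ only in configuration as drawn: 2 of 4 stereo elements differ; a stereocentre at a saturated ring carbon is drawn S in compound 2 and R in compound 3; a stereocentre at a saturated ring carbon is drawn S in compound 2 and R in compound 3. Among the compounds with values here, no measured pair differs in configuration alone, so the size of such a step in this assay is not known from these data. Within the data shown here, the only guide is indirect: a whole group on an aromatic carbon was exchanged in a number 3.8 percentage points lower from compound 1 to compound 2 (within the scatter), and this exchange did not move the read-out beyond the scatter. On that weak basis, no step beyond the scatter is expected in either direction, although a larger step cannot be ruled out. The expected step is a number 0.7 percentage points higher from compound 2 to compound 3 (within the scatter). Compound 3 is estimated at 37%, with an expected range of 24% to 50%.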

Compound 3, percent of the compound remaining: 95.9%
Beside the measured number, compound 3's estimate is 58.9 percentage points below it; measured number above the stated range.
By their numbers in this assay, from the lowest: compounds 2 and 1 (each within the scatter of the next); then compound 3.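

Reversing the two saturated ring stereocentres, from S as drawn to R as drawn, gives a number 59.6 percentage points higher from compound 2 to compound 3 (beyond the scatter) in this assay, so at this position the drawn configuration of the group of 7 heavy atoms matters far more than the earlier pair suggested. The exchange of the group of 9 heavy atoms for the group of 7 heavy atoms on the aromatic carbon gave a number 3.8 percentage points lower from compound 1 to compound 2 (within the scatter) with one drawn configuration and gives a number 55.8 percentage points higher from compound 1 to compound 3 (beyond the scatter) with the other, so the exchange has no single outcome in this series. The large step between the two isomers can be assigned to configuration and to no other structural change because of this: the fact that compounds 2 and 3 differ only in the configuration as drawn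

The compounds shown do not tell whether the high read-out belongs to this particular group of 7 heavy atoms or would also appear with a plain piperazine or a morpholine on the same aromatic carbon. They also leave open how the two stereo elements that are shared by compound 2 and compound 3 contribute, and whether each of the two reversed stereocentres could carry the step alone.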